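Ethylamino Side-Chain Variant of a Melanocortin 4 Ligand

A few compounds are considered here, and "the series" means these few. Any claim that something is new, unique, unknown or untested is made for them only; others in the source may bear on it.

Measured in an assay on HEK293 cells for displacement of a labelled ligand from Melanocortin receptor 4 (Homo sapiens); on this read-out higher numbers stand for weaker inhibition and lower numbers for stronger inhibition:
compound 1, `CCC(C)C(N)c1cc(C(F)(F)F)ccc1N1CCN(C(=O)CCc2ccc(Cl)cc2Cl)CC1`, gives 160 nM
compound 2, `NC(COCc1ccccc1)c1cc(F)ccc1N1CCN(C(=O)CCc2ccc(Cl)cc2Cl)CC1`, gives 1000 nM
compound 3, `COc1ccc(CCC(=O)N2CCN(c3ccc(C(F)(F)F)cc3[C@@H](N)CC(C)C)CC2)cc1`, gives 350 nM

Compound 1 shows the lowest number of the three, so it is the strongest binder here. Compound 3 stands nearest, yet its gap to compound 1 lies beyond the usual scatter, and compound 2 stands furthest away. The next compound, compound 4, `CCN[C@@H](CC(C)C)c1cc(C(F)(F)F)ccc1N1CCN(C(=O)CCc2ccc(Cl)cc2Cl)CC1`, differs from compound 1 in one place: 1-(ethylamino)-3-methylbutyl in place of 1-amino-2-methylbutyl on an aromatic carbon. Going by the values given here, no pair of measured compounds isolates this change, so there is no measured step to lean on. The change is modest in size, and the expectation is a step of small size or none beyond the scatter, in either direction. Compound 4 is expected to give about 220 nM, within 60 nM to 800 nM, an estimated step of a 1.4-fold higher number from compound 1 to compound 4 (0.14 log units; within the scatter).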

Compound 4, inhibition constant: 170 nM
For compound 4 the middle estimate is 1.3-fold (0.11 log units) above the measured one; low and high end bracket the measured number.
By their numbers in this assay, from the lowest: compounds 1 and 4 (each within the scatter of the next); then compound 3; then compound 2.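

In this assay, putting 1-(ethylamino)-3-methylbutyl in place of 1-amino-2-methylbutyl on this aromatic carbon gives a 1.1-fold higher number from compound 1 to compound 4 (0.03 log units; within the scatter) and stays within the usual scatter. Going by these compounds alone, this is the first direct reading at this position, and it shows that a side chain of 8 heavy atoms in place of 6 leaves the number unmoved. Nothing available here accounts for this result.

From the compounds shown here alone, compound 4 changes both the nitrogen substituent and the branch point at once, so the share of each remains unknown. Going by these compounds, whether a longer chain on that nitrogen, such as propyl or butyl, would also leave the number unmoved remains open.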